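A trifluoromethyl swap on a compound at the limit

The compounds below may be only part of what the source reports. "The series", "measured", "known", "first", "only" and "open" are said of these compounds alone.

Measured so far in an ADME assay on BJ cells (Homo sapiens) for cytotoxicity, with a stated time of 72 h; a lower number here means that less compound is needed, a higher number that more compound is needed for the effect:
Compound 1 `Cc1cc(NC(=O)Nc2cccc([N+](=O)[O-])c2)c2ccccc2n1`: > 25000 nM (a limit)
Compound 2 `Cc1cc(NC(=O)Nc2cccc(F)c2)c2ccccc2n1`: > 25000 nM (a limit)
Compound 3 `Cc1cc(NC(=O)Nc2ccc(O)cc2)c2ccccc2n1`: > 25000 nM (a limit)

In this assay compound 2 gives > 25000 nM, which is a limit of the assay and not a number. The two further values are limits too, so the evidence in hand is the limit of > 25000 nM in this assay, at which 3 of the 3 values shown sit.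

The step followed here leads to compound 4 `Cc1cc(NC(=O)Nc2cccc(C(F)(F)F)c2)c2ccccc2n1`. The change is trifluoromethyl in place of fluoro on an aromatic carbon, meta to a large group. Among the measured compounds shown here, two measured steps bear on it. The closer one is a step that the two limits leave unreadable from compound 1 to compound 2, which also exchanges one group on an aromatic carbon. The other is a step that the two limits leave unreadable from compound 2 to compound 3, a change on an amide-type nitrogen. Neither step has a readable size, so neither gives a number to carry over. All three compounds nevertheless sit at the same limit, and none goes against that, so no step beyond the scatter is expected. The estimated step is a number no higher from compound 2 to compound 4 (the limit leaves the size open). For compound 4 the estimated value is 25000 nM, with an expected range from 12000 nM to 40000 nM.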

Compound 4, half-maximal effective concentration: > 25000 nM
Compound 4 was reported as a limit; the forecaster's own chance of this, stated with the estimate: 85%; the middle value lies on the limit itself.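

In this assay, among the compounds shown here, compound 4 gives > 25000 nM, which is a limit of the assay and not a number, so no step to compound 4 from compound 1 or compound 2 can be read. The compounds shown leave open how far their true values lie from that limit and whether any of these changes shifts them: the limit of > 25000 nM in this assay, at which 4 of the 4 values shown sit.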